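A few compounds are considered here, and "the series" means these few. Any claim that something is new, unique, unknown or untested is made for them only; others in the source may bear on it.

Working notes on the hydroxycarbamoyl chain series. Going by the values given here, in a functional assay on HCT-116 cells (Homo sapiens) for inhibition, read by MTT assay, with a stated time of 72 h (on this read-out lower numbers stand for stronger inhibition and higher numbers for weaker inhibition), compound 3 (`Nc1ncnc2c1c(-c1cnc3[nH]ccc3c1)nn2CCCCCCC(=O)NO`) gives 9860 nM, the only true number so far. Compound 1 (`Nc1ncnc2c1c(-c1cnc3[nH]ccc3c1)nn2CC(=O)NO`) reads > 150000 nM, which is a limit. Compound 2 (`Nc1ncnc2c1c(-c1cnc3[nH]ccc3c1)nn2CCCCC(=O)NO`) reads > 150000 nM, again a limit.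

Next in line is compound 4 (`Nc1ncnc2c1c(-c1cnc3[nH]ccc3c1)nn2CCC(=O)NO`). Its difference from compound 3 is hydroxycarbamoyl in place of 4-(hydroxycarbamoyl)butyl on a saturated chain carbon, two bonds along the chain from an aromatic nitrogen; in words, hydroxycarbamoyl in place of 4-(hydroxycarbamoyl)butyl on a saturated chain carbon, two bonds along the chain from an aromatic nitrogen. The same difference, cut one bond further out, reads 5-(hydroxycarbamoyl)pentyl to (hydroxycarbamoyl)methyl.

Among the compounds with values here, two measured steps bear on this change: an at least 15-fold lower number from compound 1 to compound 3 (1.18 log units; beyond the scatter) and an at least 15-fold lower number from compound 2 to compound 3 (1.18 log units; beyond the scatter). Both are large, and both are read against (the limit of > 150000 nM in this assay, at which 2 of the 3 values shown sit). The remaining step, a step that the two limits leave unreadable from compound 1 to compound 2, gives no usable size.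

Read in reverse, those two steps point to a large move towards a higher number in this assay for the shortened chain, on the scale of an at least 15-fold lower number from compound 2 to compound 3 (1.18 log units; beyond the scatter). The expected change is a 15-fold higher number from compound 3 to compound 4 (1.18 log units; beyond the scatter), and a report as a bare limit is likely. For compound 4 the estimated value is 150000 nM, with an expected range from 40000 nM to 300000 nM.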

Compound 4, half-maximal inhibitory concentration: > 150000 nM
Compound 4 was reported as a limit (the forecaster's own chance of this, stated with the estimate: 80%); the middle value sits exactly at the limit.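

In this assay, replacing 4-(hydroxycarbamoyl)butyl with hydroxycarbamoyl on a saturated chain carbon, two bonds along the chain from an aromatic nitrogen, gives an at least 15-fold higher number from compound 3 to compound 4 (1.18 log units; beyond the scatter), so this shortening of the chain costs the measurable inhibition seen with compound 3. Of the four chains shown, only that of compound 3 gives a true number, and the reading for compound 4 is a limit that places it with compound 1 and compound 2, so the size of the step is itself only a minimum: the limit of > 150000 nM in this assay, at which 3 of the 4 values shown sit. The steps among compound 1, compound 2 and compound 4 cannot be read, and no order among these three can be stated.

Whether a chain longer than that of compound 3 would bring the number lower stays open, since compound 3, at 9860 nM, is the longest chain shown and no upper end of the trend is visible. Also open, as far as these compounds go, is whether a carboxylic acid or a primary amide at the chain end, in place of hydroxycarbamoyl, would keep the inhibition of compound 3.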